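From compound 1 to compound 4: one group exchanged

The compounds below may be only part of what the source reports. "The series", "measured", "known", "first", "only" and "open" are said of these compounds alone.

Measured so far in a functional assay on L1210 cells (Mus musculus) for inhibition (on this read-out higher numbers stand for weaker inhibition and lower numbers for stronger inhibition), for three compounds
compound 1 `CC(C)CN(CC(=O)N(CC(C)C)NC(=O)OCc1ccccc1)NC(=O)CBr` gives 6500 nM
compound 2 `CC(C)CN(NC(=O)OCc1ccccc1)C(=O)CN(Cc1ccccc1)NC(=O)CBr` gives 1300 nM
compound 3 `CC(C)CN(CC(=O)NN(Cc1ccccc1)c1cnccn1)NC(=O)CBr` gives 24100 nM

Compound 1 holds the middle place among these three numbers, with compound 2 lower and compound 3 higher. Compound 4 `CC(C)CN(CC(=O)N(CC(C)C)NC(=O)OCc1ccccc1)/N=C/c1ccccc1B(O)O` has not yet been measured. Its difference from compound 1 is a group of 11 heavy atoms (7 carbon, 1 boron, 1 nitrogen, 2 oxygen; one six-membered aromatic ring of carbon only) in place of a group of 5 heavy atoms (2 carbon, 1 nitrogen, 1 oxygen, 1 bromine; no ring), on an amine nitrogen in the shared core. Going by the values given here, only one measured step is at hand: a 5.0-fold lower number from compound 1 to compound 2 (0.70 log units; beyond the scatter) at a saturated chain carbon bound to an amine nitrogen, not at the group exchanged here. All three measured compounds keep the ((bromomethyl)carbonyl)amino group, so the data give no direct size for its loss. The step from compound 2 therefore serves only as a rough scale, and a step of similar modest size is expected, leaning towards a higher number with wide uncertainty. This estimate means a 2.0-fold higher number from compound 1 to compound 4 (0.30 log units; within the scatter) as the expected step. In this assay the expected value for compound 4 is 13000 nM with an estimated range from 3000 nM to 50000 nM for a measurement.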

Compound 4, half-maximal inhibitory concentration: 16200 nM
Beside the measured number, compound 4's estimate is 1.2-fold (0.10 log units) below it; the range from low to high includes it.
By their numbers in this assay, from the lowest: compound 2; then compound 1; then compounds 4 and 3 (each within the scatter of the next).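

In this assay, exchanging the ((bromomethyl)carbonyl)amino group on the amine nitrogen for the larger, ring-bearing, boron-containing group gives a 2.5-fold higher number from compound 1 to compound 4 (0.40 log units; beyond the scatter) (the first step read at this position, since the earlier step lay at a saturated chain carbon). Going by these compounds alone, the ((bromomethyl)carbonyl)amino group, kept in all the earlier compounds, is thus not needed for a measurable number in this assay: compound 4 still gives a finite value (16200 nM), and the loss on this exchange is modest. Nothing measured here accounts for the size of this step.

From the compounds shown here alone, whether a plain phenyl ring without the boron atom, or a chloroacetyl group, would hold the number at this amine nitrogen remains open. Going by these compounds, it is also open whether the phenyl-for-isopropyl gain seen at the saturated chain carbon carries over once the new group is in place.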